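Swapping furan-2-yl for 3-methylphenyl on compound 3

A few compounds are considered here, and "the series" means these few. Any claim that something is new, unique, unknown or untested is made for them only; others in the source may bear on it.

Measured in a functional assay on K562 cells (Homo sapiens) for cytotoxicity, read by ELISA, with a stated time of 4 days (on this read-out higher numbers stand for weaker inhibition and lower numbers for stronger inhibition), so far:
Compound 1 `Cc1ccsc1-c1cc(-c2ccco2)cc(-c2ccc(Cl)cc2)n1` gives 20700 nM
Compound 2 `Cc1ccsc1-c1cc(-c2ccoc2)cc(-c2ccco2)n1` gives 23300 nM
Compound 3 `Clc1ccc(-c2cc(-c3ccoc3)cc(-c3ccco3)n2)s1` gives 16200 nM

Compound 3 stands level with the other two compounds, since all three values lie within the scatter of one another. The next compound is compound 4 `Cc1cccc(-c2cc(-c3ccoc3)cc(-c3ccc(Cl)s3)n2)c1`, which differs from compound 3 by 3-methylphenyl in place of furan-2-yl on an aromatic carbon. Within the data shown here, the only measured step, a 1.4-fold lower number from compound 2 to compound 3 (0.16 log units; within the scatter), lies within the scatter and concerns a different group, so it offers only weak guidance here. No step beyond the scatter is therefore expected in this assay. The step is estimated as a 1.2-fold lower number from compound 3 to compound 4 (0.06 log units; within the scatter) and no more. For compound 4 the expected value is 14000 nM, with an estimated range from 6000 nM to 30000 nM.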

Compound 4, half-maximal inhibitory concentration: 13700 nM
Beside the measured number, compound 4's estimate is 1.0-fold (0.01 log units) above it; the range from low to high includes it.
By their numbers in this assay, from the lowest: compounds 4, 3, 1 and 2 (each within the scatter of the next).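

In this assay, putting 3-methylphenyl in place of furan-2-yl, on the aromatic carbon next to the ring nitrogen, gives a 1.2-fold lower number from compound 3 to compound 4 (0.07 log units; within the scatter). So at this position, a six-membered aromatic ring of carbon only with no hydrogen-bond acceptor stands level with a five-membered aromatic ring carrying one, a change of group the earlier compounds did not show here. No evidence is available to explain this result. The compounds shown leave open whether an amine or a carboxylic acid at this position would produce a step beyond the scatter.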